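Series notes: compound 4 and the 4-fluorobenzyl ether

The source may hold more compounds than are shown below. What is called first, only, known or untested is meant among the compounds shown, and "the series" means these compounds.

Measured so far in a functional assay on HEK293 cells for agonist activity at G-protein coupled receptor 39 (Homo sapiens), read by scintillation proximity assay and inositol phosphate accumulation, with a stated time of 75 min; a lower number here means that less compound is needed, a higher number that more compound is needed for the effect:
compound 1, `Cc1nn(-c2ncnc3nc[nH]c23)c2c1C(OCc1ccc(Cl)cc1Cl)CC(=O)N2`: 243 nM
compound 2, `Cc1nn(-c2ncnc3nc[nH]c23)c2c1C(OC1CCCC1)CC(=O)N2`: 62 nM
compound 3, `Cc1nn(-c2ncnc3nc[nH]c23)c2c1C(C(=O)NCc1ccccc1)CC(=O)N2`: 2930 nM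

Compound 1 stands second highest of the three numbers; nearest is a 3.9-fold lower number from compound 1 to compound 2 (0.59 log units; beyond the scatter), furthest is a 12-fold higher number from compound 1 to compound 3 (1.08 log units; beyond the scatter). Compound 4, `Cc1nn(-c2ncnc3nc[nH]c23)c2c1C(OCc1ccc(F)cc1)CC(=O)N2`, keeps the ether and alters only the aromatic part: 4-fluorophenyl in place of 2,4-dichlorophenyl on a saturated chain carbon bound to an oxygen on a saturated carbon. Within the data shown here, no measured step varies chlorine against fluorine on that ring. The steps at the same carbon, a 3.9-fold lower number from compound 1 to compound 2 (0.59 log units; beyond the scatter), a 12-fold higher number from compound 1 to compound 3 (1.08 log units; beyond the scatter) and a 47-fold higher number from compound 2 to compound 3 (1.67 log units; beyond the scatter), show the two ether-linked groups giving the lower numbers and benzylcarbamoyl the highest, but say nothing about substituents on the aromatic ring. For compound 4 a step within the scatter, or a small one either way, is therefore expected: a 1.2-fold higher number from compound 1 to compound 4 (0.09 log units; within the scatter). The estimate for compound 4 in this assay is 300 nM, ranging from 100 nM to 900 nM.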

Compound 4, half-maximal effective concentration: 126 nM
For compound 4 the middle estimate is 2.4-fold (0.38 log units) above the measured one, within the range that was stated.
By their numbers in this assay, from the lowest: compound 2; then compounds 4 and 1 (each within the scatter of the next); then compound 3.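

Changing the aromatic part of the benzyl ether barely registers in this assay (a 1.9-fold lower number from compound 1 to compound 4 (0.29 log units; within the scatter)), so 4-fluorophenyl and 2,4-dichlorophenyl are not separated at this position. A second benzyl ether also stays well under the benzylcarbamoyl compound (a 23-fold lower number from compound 3 to compound 4 (1.37 log units; beyond the scatter)), which extends the ether-over-amide gap beyond compounds 1 and 2. Cyclopentyl on the oxygen keeps a modest edge over 4-fluorobenzyl (a 2.0-fold higher number from compound 2 to compound 4 (0.31 log units; beyond the scatter)).

As far as these compounds go, whether a methoxy group on the benzyl ring, or an amine on a longer chain in place of the benzyl group, would shift the number remains open. Nothing available explains the size of these steps.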